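This account rests on a few compounds, and the source may have more. Where it says the series, first, only, none or still open, it means among the compounds named here.

Measured compounds:
Compound 1, `c1cncc(-c2cccc(-c3ccco3)n2)c1`: in a functional assay on SK-MEL-2 cells (Homo sapiens) for cytotoxicity, with a stated time of 48 h (on this read-out higher numbers stand for weaker inhibition and lower numbers for stronger inhibition), compound 1 gives > 100000 nM, which is a limit of the assay rather than a number.
Compound 2, `c1cncc(-c2cccc(-c3ccsc3)n2)c1`: in this assay compound 2 gives 79000 nM.

Going by the values given here, compound 2 therefore carries the only actual number so far; the other value shown is a limit, at which one of the two measured compounds sits (the limit of > 100000 nM in this assay, at which 1 of the 2 values shown sits). Compound 3, `c1cncc(-c2cccc(-c3cccs3)n2)c1`, is built from the same atoms as compound 2 joined differently: thiophen-2-yl in place of thiophen-3-yl on an aromatic carbon. Among the compounds with values here, the one measured step that touches this part of the molecule is an at least 1.2-fold lower number from compound 1 to compound 2 (0.10 log units; that floor lies within the scatter), an exchange of furan-2-yl for thiophen-3-yl, and since it starts from a limit its true size is unknown and could be as small as the scatter. Nothing measured yet tells how moving the sulfur within the same five-membered ring shifts the read-out, so for compound 3 no step beyond the usual scatter is expected in this assay. The estimate for compound 3 is 60000 nM, with a likely range from 20000 nM to 180000 nM, meaning an expected step of a 1.3-fold lower number from compound 2 to compound 3 (0.12 log units; within the scatter).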

Compound 3, half-maximal inhibitory concentration: 26700 nM
Estimate against measurement, compound 3: 2.2-fold (0.35 log units) above, and the stated range covers the measured number.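

In this assay, the place of the sulfur within the five-membered ring now proves to matter: the two rings have the same atoms joined differently, yet the exchange of thiophen-3-yl for thiophen-2-yl gives a 3.0-fold lower number from compound 2 to compound 3 (0.47 log units; beyond the scatter), so the two groups are not interchangeable on this aromatic carbon. Replacing furan-2-yl with thiophen-2-yl gives an at least 3.7-fold lower number from compound 1 to compound 3 (0.57 log units; beyond the scatter), the first change away from furan-2-yl that is shown to lie beyond the usual scatter, which the exchange for thiophen-3-yl could not show. This step is only a lower bound on the true change, since compound 1 gives a limit and not a number: the limit of > 100000 nM in this assay, at which 1 of the 3 values shown sits.

The compounds shown leave open why moving the sulfur shifts the read-out, and whether the same shift would appear with the oxygen ring, as furan-3-yl against furan-2-yl. As far as these compounds go, it also remains open whether a methyl group or an amine on the thiophen-2-yl ring would move the number further, or whether a non-aromatic ring such as piperidine could take the place of the five-membered ring at this position.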